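A few compounds are considered here, and "the series" means these few. Any claim that something is new, unique, unknown or untested is made for them only; others in the source may bear on it.

Measured in a functional assay on ECa-109 cells for inhibition, with ECa-109 cell line (Homo sapiens) as the target, read by sulforhodamine B assay; on this read-out lower numbers stand for stronger inhibition and higher numbers for weaker inhibition:
compound 1 `CCCc1ccc(NC2=CC(=O)c3nc4n(c3C2=O)[C@H]2OC[C@@H](O)[C@H]2OC4)cc1`: > 4000 nM (a limit of the assay)
compound 2 `O=C1C=C(Nc2ccccc2F)C(=O)c2c1nc1n2[C@H]2OC[C@@H](O)[C@H]2OC1`: 2760 nM
compound 3 `CCc1ccc(NC2=CC(=O)c3nc4n(c3C2=O)[C@H]2OC[C@@H](O)[C@H]2OC4)cc1`: 3080 nM

Compound 3, at 3080 nM, lies within the scatter of compound 2, at 2760 nM. For compound 1 the entry is only a limit, > 4000 nM.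

Next in the series is compound 4 `O=C1C=C(Nc2cccc(F)c2)C(=O)c2c1nc1n2[C@H]2OC[C@@H](O)[C@H]2OC1`, with 3-fluorophenyl in place of 4-ethylphenyl on an amine nitrogen.

The closest measured change is an exchange of the same kind on that nitrogen, 4-ethylphenyl in place of 2-fluorophenyl: a 1.1-fold higher number from compound 2 to compound 3 (0.05 log units; within the scatter). The two steps that start from the limit give only floors: an at least 1.4-fold lower number from compound 1 to compound 2 (0.16 log units; that floor lies within the scatter), and an at least 1.2-fold lower number from compound 1 to compound 3 (0.11 log units; that floor lies within the scatter). None of these steps leaves the scatter, so no step beyond the scatter is expected in this assay, and no direction can be given with confidence. The estimated step is a 1.1-fold lower number from compound 3 to compound 4 (0.06 log units; within the scatter).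

For compound 4 the expected value is 2700 nM, with an expected range of 1400 nM to 4000 nM.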

Compound 4, half-maximal inhibitory concentration: 7030 nM
Compound 4: middle estimate off by 2.6-fold (0.42 log units), on the low side, outside the stated range (above it).
By their numbers in this assay, from the lowest: compounds 2 and 3 (each within the scatter of the next); then compound 4.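

In this assay, a change of the aryl group on the amine nitrogen now gives a step beyond the scatter, though a modest one: a 2.3-fold higher number from compound 3 to compound 4 (0.36 log units; beyond the scatter), and a 2.5-fold higher number from compound 2 to compound 4 (0.41 log units; beyond the scatter). Within the data shown here, the second of these steps only exchanges 2-fluorophenyl for 3-fluorophenyl, so the ring place of the fluorine matters at this nitrogen, which the earlier steps, all within the scatter or reduced to floors, did not show. The step to compound 4 from compound 1 cannot be read, since compound 1 carries only a limit: the limit of > 4000 nM in this assay, at which 1 of the 4 values shown sits.

Open, from the compounds shown here alone, is where 4-fluorophenyl would fall at this nitrogen, which would complete the fluorine series. Also open, going by these compounds, is whether 3-chlorophenyl or 3-methoxyphenyl would follow 3-fluorophenyl, or whether the higher number belongs to fluorine alone.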